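Moving the acid and swapping methoxy for fluorine

The source may report more compounds than this note shows. Statements on the series, on what has been measured and on what is new or still open speak of the compounds shown alone.

Compound 1 `COc1ccc(C(=O)O)cc1OCCCCOc1ccc(C(=O)CC2CCCC2)c(O)c1C`: 425 nM
Compound 2 `COc1ccc(C(=O)O)cc1OCCCCOc1ccc(C(=O)CC(C)C)c(O)c1C`: 155 nM

Going by the values given here, in an assay on HEK293 cells for positive allosteric modulation of metabotropic glutamate receptor 2 (Rattus norvegicus), read by thallium flux, with a stated time of 2.5 min (a higher number here means that more compound is needed for the effect, a lower number that less compound is needed), compound 1 gives 425 nM, the highest of the two numbers measured so far, and compound 2 gives 155 nM. Among the compounds with values here, the single measured step, a 2.7-fold lower number from compound 1 to compound 2 (0.44 log units; beyond the scatter), changes the saturated end of the molecule near the carbonyl, not the aromatic acid end, so it gives no direct guidance for the change now considered. Compound 3 `Cc1c(OCCCCOc2ccc(F)c(C(=O)O)c2)ccc(C(=O)CC2CCCC2)c1O` differs from compound 1 at that aromatic end: 3-carboxy-4-fluorophenyl in place of 5-carboxy-2-methoxyphenyl on an oxygen on a saturated carbon. Within the data shown here, no measured step touches this part of the molecule, so nothing here points to a direction. The expectation for compound 3 is therefore a number close to that of compound 1, with a 1.2-fold higher number from compound 1 to compound 3 (0.07 log units; within the scatter) expected to stay within the scatter, though with a wide allowance. Compound 3 is estimated at 500 nM, with a range from 150 nM to 1700 nM.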

Compound 3, half-maximal effective concentration: 699 nM
Compound 3: the middle estimate sits 1.4-fold (0.15 log units) below what was measured; low and high end bracket the measured number.
By their numbers in this assay, from the lowest: compound 2; then compounds 1 and 3 (each within the scatter of the next).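

Going by these compounds alone, this is the first change at the aromatic end of the molecule, and in this assay it gives a 1.6-fold higher number from compound 1 to compound 3 (0.22 log units; within the scatter). The swap of 5-carboxy-2-methoxyphenyl for 3-carboxy-4-fluorophenyl alters both where the carboxy group stands on the ring and which second group it carries, yet the two compounds cannot be told apart in this assay. Nothing available explains this result, and it cannot show whether the two alterations each leave the number alone or offset one another.

Every compound shown carries a carboxylic acid on this ring, so whether an amide or a tetrazole there would give a similar number remains open. Also open, going by these compounds, is whether the 3-carboxy-4-fluorophenyl group would behave the same alongside the isopropyl of compound 2.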